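Amine swap at the thiocarbonyl carbon of compound 1

This account rests on a few compounds, and the source may have more. Where it says the series, first, only, none or still open, it means among the compounds named here.

Measured so far:
compound 1 `O=c1cc(CSC(=S)N2CCCCC2)oc2cc(Cl)ccc12` — 3000 nM
compound 3 `O=c1c(CSC(=S)N2CCCC2)coc2ccccc12` — 3800 nM
compound 2 `O=c1cc(CSC(=S)N2CCCCC2)oc2ccccc12` — a limit of the assay, > 25000 nM

In a functional assay on MDA-MB-435S cells (Homo sapiens) for antiproliferative activity, read by MTT assay, with a stated time of 72 h (a lower number here means a stronger inhibitor, a higher number a weaker inhibitor), compound 1 holds the lowest of the two numbers; compound 3 sits within the scatter of it, so no order is claimed. For the measured compounds named here, the only measured step, an at least 8.3-fold higher number from compound 1 to compound 2 (0.92 log units; beyond the scatter), concerns the chloro and says nothing about the amine. Compound 4 `CC(C)N(C(=S)SCc1cc(=O)c2ccc(Cl)cc2o1)C(C)C` differs from compound 1 by diisopropylamino in place of piperidin-1-yl on a thiocarbonyl carbon. Compound 3 differs from compound 1 in more than one place, so only its value is known. Going by the values given here, with no step touching the amine, the expected step of no change at the digits printed from compound 1 to compound 4 (within the scatter) is none beyond the scatter. Compound 4 is estimated at 3000 nM, between 1200 nM and 8000 nM.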

Compound 4, half-maximal inhibitory concentration: > 25000 nM
Compound 4 was reported as a limit (the forecaster's own chance of this, stated with the estimate: 10%); middle value at least 8.3-fold (0.92 log units) from the limit.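

At this position the amine is not interchangeable: diisopropylamino in place of piperidin-1-yl on a thiocarbonyl carbon gives an at least 8.3-fold higher number from compound 1 to compound 4 (0.92 log units; beyond the scatter) in this assay. Until now only the chloro had a measured step, and the chloro alone does not hold the number of compound 1. The value of compound 4 is a limit of the assay and not a number: the limit of > 25000 nM in this assay, at which 2 of the 4 values shown sit.

Open, on these data alone, is whether a morpholin-4-yl ring or an unbranched diethylamino group would hold the number of compound 1 on the same core. Pyrrolidin-1-yl appears only in compound 3, which differs from compound 1 in more than one place, so its effect on this core also remains open.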